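The compounds below may be only part of what the source reports. "The series", "measured", "known", "first", "only" and "open" are said of these compounds alone.

Measured compounds:
compound 1 `CSCC/C=N/NC(=O)c1cnc2c(C(F)(F)F)cccc2c1N[C@@H](CSc1ccccc1)CC(=O)N(C)C` — in an ADME assay on Vero cells (Chlorocebus sabaeus) for cytotoxicity, read by MTT assay, with a stated time of 72 h (a higher number here means a weaker inhibitor, a lower number a stronger inhibitor), compound 1 shows "not determined" (no result reported)
compound 2 `CN(C)C(=O)C[C@H](CSc1ccccc1)Nc1c(C(=O)N/N=C/c2ccc(F)cc2)cnc2ccc(F)cc12` — in this assay compound 2 reaches only a limit, > 62.5 ug/mL
compound 3 `CN(C)C(=O)C[C@H](CSc1ccccc1)Nc1c(C(=O)N/N=C/c2ccc(Br)s2)cnc2ccc(F)cc12` — in this assay compound 3 shows "not determined" (no result reported)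

Compound 3 thus stands without a number: of its two companions, compound 2 gives a limit rather than a value, and compound 1 gives no result at all (the limit of > 62.5 ug/mL in this assay, at which 1 of the 3 values shown sits). Compound 4 `CCCCCCCC/C=N/NC(=O)c1cnc2ccc(F)cc2c1N[C@@H](CSc1ccccc1)CC(=O)N(C)C` differs from compound 3 in one place, (octyl in place of 5-bromothiophen-2-yl on a carbon with a double bond to nitrogen), octyl in place of 5-bromothiophen-2-yl on a carbon with a double bond to nitrogen. With no measured step between any two of these compounds, no change beyond the usual scatter in this assay is expected from this replacement. Compound 4 is therefore estimated at 70 ug/mL, within 25 ug/mL to 150 ug/mL.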

Compound 4, half-maximal inhibitory concentration: > 62.5 ug/mL
Compound 4 was reported as a limit; the forecaster's own chance of this, stated with the estimate: 60%; the middle value is on the limit's open side.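

In this assay, among the compounds shown here, compound 2 and compound 4 both end at a limit rather than a number, so no step between them can be read: the limit of > 62.5 ug/mL in this assay, at which 2 of the 4 values shown sit.

Going by these compounds, whether swapping 4-fluorophenyl for octyl changes cytotoxicity at all remains open.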